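The compounds below may be only part of what the source reports. "The series", "measured", "known", "first", "only" and "open" are said of these compounds alone.

Three compounds share one core, and each has been tested in an assay on isolated protein for inhibition of high affinity 3',5'-cyclic-AMP phosphodiesterase 7A (Homo sapiens), read by cAMP accumulation, with a stated time of 10 min; on this read-out higher numbers stand for weaker inhibition and lower numbers for stronger inhibition. Compound 1 `COc1nc2c(c(=O)n(C)c(=O)n2C)n1CC(=O)Nc1ccc(C(C)(C)C)cc1` gives in this assay only a limit of the measurement, > 200000 nM. Compound 2 `COc1nc2c(c(=O)n(C)c(=O)n2C)n1CC(=O)Nc1ccc(C(C)C)cc1` likewise gives only a limit in this assay, > 200000 nM. Compound 3 `CCOc1nc2c(c(=O)n(C)c(=O)n2C)n1CC(=O)Nc1ccc(Cl)cc1` also stands at a limit in this assay, > 200000 nM. The change from compound 1 to compound 2, hydrogen in place of methyl on a saturated chain carbon bound to an aromatic carbon and two saturated chain carbons, gives a step that the two limits leave unreadable from compound 1 to compound 2, so its size cannot be read. All three values sit at the same point, namely (the limit of > 200000 nM in this assay, at which 3 of the 3 values shown sit).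

Compound 4 `CCOc1nc2c(c(=O)n(C)c(=O)n2C)n1CC(=O)NCc1ccccc1Cl` is not yet measured. It differs from compound 3 by 2-chlorobenzyl in place of 4-chlorophenyl on an amide-type nitrogen: the group on the amide-type nitrogen changes from (4-chlorophenyl)amino to (2-chlorobenzyl)amino. Within the data shown here, no measured step bears on this change in a readable way. Among the measured compounds shown here, the only comparison between measured compounds runs between two limits. For the measured compounds named here, none of the measured compounds shows a number inside the range of this assay, so there is no basis to expect a readable step in either direction. The expectation is that compound 4 will most likely also return a limit. As a working estimate, the step is expected to be a number no higher from compound 3 to compound 4 (the limit leaves the size open). Compound 4 is therefore estimated at 200000 nM, with a range from 30000 nM to 600000 nM.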

Compound 4, half-maximal inhibitory concentration: > 200000 nM
Compound 4: a limit, no number; the forecaster's own chance of this, stated with the estimate: 80%; the middle value lies on the limit itself.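

Compound 4 gives only a limit in this assay, > 200000 nM. Compound 3 also stands at a limit, so the size of the change from compound 3 to compound 4 cannot be read. The compounds shown leave open whether any group on this shared core gives a readable number, as every result sits at one point: the limit of > 200000 nM in this assay, at which 4 of the 4 values shown sit.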